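Removal of the fluoro substituent in compound 1's series

The source may report more compounds than this note shows. Statements on the series, on what has been measured and on what is new or still open speak of the compounds shown alone.

Measured compounds in a functional assay on cells (T-cell, Mus musculus, strain BALB/c) for inhibition, read by MTT assay, with a stated time of 72 h; on this read-out lower numbers stand for stronger inhibition and higher numbers for weaker inhibition:
compound 1 `COC(=O)c1cc(F)ccc1OC(=O)COc1cc(O)c2c(=O)cc(-c3ccccc3)oc2c1` gives 6820 nM
compound 2 `COC(=O)c1cc(O)ccc1OC(=O)COc1cc(O)c2c(=O)cc(-c3ccccc3)oc2c1` gives 29500 nM
compound 3 `COC(=O)c1ccc(Br)cc1OC(=O)COc1cc(O)c2c(=O)cc(-c3ccccc3)oc2c1` gives 17600 nM

Compound 1 stands lowest of the three numbers in this assay; compound 3 is nearest to it and compound 2 furthest. The step to compound 4 `COC(=O)c1ccccc1OC(=O)COc1cc(O)c2c(=O)cc(-c3ccccc3)oc2c1` is the change (hydrogen in place of fluoro on an aromatic carbon).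

Going by the values given here, two measured steps bear on this. The step of a 4.3-fold higher number from compound 1 to compound 2 (0.64 log units; beyond the scatter) replaces the same fluoro with a different group and is beyond the scatter. The step of a 2.6-fold higher number from compound 1 to compound 3 (0.41 log units; beyond the scatter) exchanges the whole fluoro-bearing ring fragment for a bromo-bearing one and is also beyond the scatter. Both departures from compound 1 gave higher numbers, but neither removes the substituent outright, so the size of the present step is uncertain. A modest rise is expected, smaller than that seen for compound 2, possibly within the scatter.

Compound 4 is therefore estimated at 11000 nM, range 4500 nM to 27000 nM, meaning an expected step of a 1.6-fold higher number from compound 1 to compound 4 (0.21 log units; within the scatter).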

Compound 4, half-maximal inhibitory concentration: 28500 nM
The estimate for compound 4 lay 2.6-fold (0.41 log units) below the measured number; measured number above the stated range.
By their numbers in this assay, from the lowest: compound 1; then compounds 3, 4 and 2 (each within the scatter of the next).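

In this assay, taking the fluoro away altogether gives a 4.2-fold higher number from compound 1 to compound 4 (0.62 log units; beyond the scatter), so the low number of compound 1 is tied to the fluoro on this aromatic carbon, meta to the methoxycarbonyl group, and is not carried by the shared core alone. Hydroxy adds nothing beyond the scatter over hydrogen, with a 1.0-fold lower number from compound 2 to compound 4 (0.01 log units; within the scatter), and the same holds for bromo, with a 1.6-fold higher number from compound 3 to compound 4 (0.21 log units; within the scatter), so among these four compounds only the fluoro compound stands apart. No measurement at hand accounts for this difference.

From the compounds shown here alone, whether the effect is particular to fluoro stays open; chloro, methyl or methoxy on the same carbon would show this. Also open, going by these compounds, is how far the result depends on the methoxycarbonyl group, which a carboxylic acid or an amide in its place would test.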